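Cytotoxicity limits and a hydroxy swap on a saturated ring

A few compounds are considered here, and "the series" means these few. Any claim that something is new, unique, unknown or untested is made for them only; others in the source may bear on it.

Values measured in an ADME assay on Vero cells (Chlorocebus sabaeus) for cytotoxicity; on this read-out lower numbers stand for higher toxicity in this test and higher numbers for lower toxicity in this test:
Compound 1 `Nc1nc(F)cc2c1ncn2[C@@H]1C=C(CCO)[C@@H](O)[C@H]1O`: > 100000 nM (a limit)
Compound 2 `Nc1ncc(F)c2c1ncn2[C@@H]1C=C(CO)[C@@H](O)[C@H]1O`: 224000 nM
Compound 3 `Nc1nc(F)cc2c1ncn2[C@@H]1C[C@H](CO)[C@@H](O)[C@H]1O`: > 355000 nM (a limit)

Compound 3 stands at > 355000 nM, which is a limit of the assay and not a number. Compound 1 also gives only a limit, > 100000 nM. Within the data shown here, compound 2 gives 224000 nM, the only plain number of the three.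

The next compound, compound 4 `Nc1nc(F)cc2c1ncn2[C@@H]1C[C@H](O)[C@@H](O)[C@H]1O`, departs from compound 3 at one place: hydroxy in place of hydroxymethyl on a saturated ring carbon. In words, this is hydroxy in place of hydroxymethyl on a saturated ring carbon. Among the measured compounds shown here, no pair of measured compounds shows what such a change does in this assay, so the expectation rests on the three results alone. For the measured compounds named here, none of them points to marked toxicity, and compound 2 at 224000 nM offers the one numerical guide. No change beyond the usual scatter is expected, and the estimated step is an at least 1.1-fold lower number from compound 3 to compound 4 (0.07 log units; that floor lies within the scatter). Compound 4 is expected to reach about 300000 nM, within an estimated range of 120000 nM to 550000 nM.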

Compound 4, half-maximal cytotoxic concentration: > 100000 nM
Compound 4: a limit, no number (the forecaster's own chance of this, stated with the estimate: 70%); the middle value is on the limit's open side.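

In this assay compound 3 gives > 355000 nM, which is a limit and not a number. Compound 4 gives > 100000 nM, also a limit. No step can be read from compound 3 to compound 4. The compounds shown leave open what hydroxy in place of hydroxymethyl on a saturated ring carbon does to cytotoxicity.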